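Growing the side group of compound 2

The compounds below may be only part of what the source reports. "The series", "measured", "known", "first", "only" and "open" are said of these compounds alone.

compound 1 `C#CCOc1ccc2c(=O)c(-c3cc(OC)c(OC)cc3OC)coc2c1` gives 4950 nM
compound 2 `COc1cc(OC)c(-c2coc3cc(OCc4ccccc4)ccc3c2=O)cc1OC` gives 1320 nM

In a functional assay on HepG2 cells (Homo sapiens) for antiproliferative activity, read by MTT assay, with a stated time of 24 h (on this read-out lower numbers stand for stronger inhibition and higher numbers for weaker inhibition), compound 2 stands lowest of the two measured compounds with 1320 nM as its number. Compound 3 `COc1cc(OC)c(-c2coc3cc(OCC(=O)c4cccc(C(F)(F)F)c4)ccc3c2=O)cc1OC` shares the core of compound 2 but carries (3-(trifluoromethyl)phenyl)carbonyl in place of phenyl on a saturated chain carbon bound to an oxygen on an aromatic ring. Within the data shown here, the only measured step at this place is a 3.8-fold lower number from compound 1 to compound 2 (0.57 log units; beyond the scatter) with phenyl in place of ethynyl, a modest change but beyond the scatter. That step shows that the number can move when this group changes, yet it says little about the new group. In this assay a modest step is therefore expected, more likely towards a lower number than a higher one. The estimate amounts to a 1.5-fold lower number from compound 2 to compound 3 (0.17 log units; within the scatter) as an expected step. For compound 3 the estimated value is 900 nM (expected range 250 nM to 3500 nM).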

Compound 3, half-maximal inhibitory concentration: > 10000 nM
Compound 3 gave a limit, no number; the forecaster's own chance of this, stated with the estimate: 5%; middle value at least 11-fold (1.04 log units) away from the limit.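

In this assay, the place on a saturated chain carbon bound to an oxygen on an aromatic ring turns out to tolerate change poorly as well as to reward it: (3-(trifluoromethyl)phenyl)carbonyl in place of phenyl gives an at least 7.5-fold higher number from compound 2 to compound 3 (0.87 log units; beyond the scatter). Compound 3 gives a limit of the assay, not a number: the limit of > 10000 nM in this assay, at which 1 of the 3 values shown sits. The comparison with the ethynyl group gives an at least 2.0-fold higher number from compound 1 to compound 3 (0.30 log units; that floor lies within the scatter), a floor too small to set those two compounds apart.

This change brought in a carbonyl and a trifluoromethyl group together, and the compounds shown do not separate the two. As far as these compounds go, whether a plain phenylcarbonyl group, or a phenyl ring carrying an amine or a carboxylic acid, would stay close to compound 2 remains open.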